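The compounds below may be only part of what the source reports. "The series", "measured", "known", "first", "only" and "open" are said of these compounds alone.

The study follows a series built on the shared core of compound 3 `CCOC(=O)Nc1ccc([Se]C#N)cc1` and asks how the group on the oxygen next to the carbonyl shapes the read-out in a physicochemical assay, with a stated time of 6 min, tested at 0.1 mg/mL; on this read-out higher numbers stand for more inhibition at the one concentration tested (going by the name of the read-out) and lower numbers for less inhibition. Among the compounds with values here, compound 3 is the only member with a number in this assay, where compound 3 gives 26.3%. Compound 1 `N#C[Se]c1ccc(NC(=O)Oc2ccc(F)cc2)cc1` gives in this assay > 25%, which is a limit of the assay and not a number. Compound 2 `N#C[Se]c1ccc(NC(=O)Oc2ccc(Cl)cc2)cc1` likewise gives in this assay > 25%, again a limit. The step that the two limits leave unreadable from compound 1 to compound 2 stays unreadable because of the limit of > 25% in this assay, at which 2 of the 3 values shown sit. Compound 4 `N#C[Se]c1ccc(NC(=O)Oc2ccccc2)cc1` has not yet been measured. It differs from compound 3 as follows: phenyl in place of ethyl on an oxygen next to a carbonyl group. Within the data shown here, no measured step bears directly on this change; the single measured step concerns chloro in place of fluoro on an aromatic carbon, and its size is hidden by the limits. Since compound 1 and compound 2 sit at the limit while compound 3 sits near it, putting phenyl in place of ethyl is not expected to move the read-out far. Compound 4 is therefore expected to show a step of a number 3.7 percentage points higher from compound 3 to compound 4 (within the scatter) in this assay, within the scatter. Compound 4 is estimated at 30% in this assay, with a range from 20% to 45%, and a fair chance that only a limit is returned.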

Compound 4, a percentage reported as inhibition, at one concentration (the size of the read-out at that concentration, not a potency): > 25%
Compound 4: only a limit was reported (the forecaster's own chance of this, stated with the estimate: 55%); the middle value does not contradict the limit.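

The result for compound 4 in this assay is a limit and not a number, so its steps to compound 1, compound 2 and compound 3 cannot be read: the limit of > 25% in this assay, at which 3 of the 4 values shown sit. The compounds shown leave open whether phenyl in place of ethyl on an oxygen next to a carbonyl group changes the read-out at all, and by how much.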